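The compounds below may be only part of what the source reports. "The series", "measured", "known", "first", "only" and "open" are said of these compounds alone.

In an assay on Prostate gland (Oryctolagus cuniculus) for inhibition of Adrenergic receptor alpha-1 (Homo sapiens) (on this read-out lower numbers stand for tighter binding and higher numbers for weaker binding), compound 1 `COc1ccccc1N1CCN(CCC(Oc2ccc(C(=O)Nc3ccccc3OCCCC(=O)O)cc2)c2ccccc2)CC1` gives 25.1 nM, and compound 2 `COc1ccccc1N1CCN(CCC(Oc2ccc(C(=O)Nc3ccccc3OCCCC(=O)O)cc2)c2cccc(C)c2)CC1` gives 251 nM, the higher of the two numbers. Within the data shown here, the one measured step, a 10-fold higher number from compound 1 to compound 2 (1.00 log units; beyond the scatter), shows that adding a methyl to this phenyl raises the number. Compound 3 `CCc1ccc(C(CCN2CCN(c3ccccc3OC)CC2)Oc2ccc(C(=O)Nc3ccccc3OCCCC(=O)O)cc2)cc1` carries 4-ethylphenyl in place of 3-methylphenyl on a saturated chain carbon bound to an oxygen on an aromatic ring and a saturated chain carbon. Among the measured compounds shown here, no measured step covers a substituent at this new position or the ethyl group, so the only guide is compound 2 and its value 251 nM. For compound 3 the expected outcome in this assay is 320 nM, with a range of 100 nM to 1000 nM, an expected step of a 1.3-fold higher number from compound 2 to compound 3 (0.11 log units; within the scatter).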

Compound 3, dissociation constant: 39.8 nM
For compound 3 the middle estimate is 8.0-fold (0.91 log units) above the measured one; measured number below the stated range.
By their numbers in this assay, from the lowest: compounds 1 and 3 (each within the scatter of the next); then compound 2.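

In this assay a group on this phenyl does not by itself raise the number: ethyl in place of hydrogen gives a 1.6-fold higher number from compound 1 to compound 3 (0.20 log units; within the scatter) and 4-ethylphenyl in place of 3-methylphenyl gives a 6.3-fold lower number from compound 2 to compound 3 (0.80 log units; beyond the scatter). The higher number of compound 2 therefore does not extend to compound 3. Nothing measured here accounts for the difference between these two groups. Going by these compounds, compound 2 and compound 3 differ in both the place and the size of the group, so it stays open which of these matters. On these data alone, how 4-methylphenyl, 3-ethylphenyl or a methoxy group on this phenyl would read also stays open.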